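The source may report more compounds than this note shows. Statements on the series, on what has been measured and on what is new or still open speak of the compounds shown alone.

Compound 2 `O=C1C=CC[C@H]([C@@H]2C[C@H]2c2ccccc2)O1` is the starting point, and in a functional assay on MCF7 cells (Homo sapiens) for antiproliferative activity, read by luminescence and CellTiter-Glo, with a stated time of 48 h (on this read-out higher numbers stand for weaker inhibition and lower numbers for stronger inhibition), compound 2 gives > 100000 nM. That reading is a limit of the assay and not a number. In this assay compound 1 `O=C1CCC[C@@H]([C@H]2C[C@@H]2c2ccccc2)O1` gives > 100000 nM, which is also a limit. In this assay compound 3 `O=C1CCC[C@H]([C@@H]2C[C@H]2c2ccccc2)O1` gives > 100000 nM, again a limit. The whole picture so far is the limit of > 100000 nM in this assay, at which 3 of the 3 values shown sit, so these three compounds cannot be ranked against one another.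

Compound 4 `O=C1C=CC[C@@H]([C@H]2C[C@@H]2c2ccccc2)O1` is the mirror image of compound 2: the two compounds have the same atoms and bonds and differ only in configuration as drawn: 3 of 3 stereo elements differ (all stereocentres are inverted: mirror images); a stereocentre at a saturated ring carbon is drawn R in compound 2 and S in compound 4; a stereocentre at a saturated ring carbon is drawn R in compound 2 and S in compound 4; a stereocentre at a saturated ring carbon is drawn R in compound 2 and S in compound 4. Among the measured compounds shown here, the only measured comparison of this kind is a step that the two limits leave unreadable from compound 1 to compound 3, and it rests on (the fact that compounds 1 and 3 differ only in the configuration as drawn). Neither partner of that mirror-image pair reached a readable value, so it gives no size to carry over, only a precedent of inversion without a readable result. No step beyond the usual scatter can therefore be predicted in this assay, and compound 4 is expected to stay close to the same limit, quite possibly reported only as a limit. For compound 4 the estimate is 100000 nM, with an expected range from 30000 nM to 150000 nM. The expected change is a number no higher from compound 2 to compound 4 (the limit leaves the size open).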

Compound 4, half-maximal inhibitory concentration: 68300 nM
Compound 4: middle estimate off by 1.5-fold (0.17 log units), on the high side; measured number inside the range.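

Inverting all three stereocentres gives an at least 1.4-fold lower number from compound 2 to compound 4 (0.16 log units; that floor lies within the scatter) in this assay and so places the first readable number in this series on one partner of a mirror-image pair. Among the compounds shown here, that floor stays within the usual scatter, so the data do not establish that compound 4 inhibits more strongly than compound 2; they show only that this pair, unlike compounds 1 and 3, has one member that yields a number. The comparison is a clean test of configuration alone, with no group entering or leaving: the fact that compounds 2 and 4 differ only in the configuration as drawn.

As far as these compounds go, the step between compounds 1 and 3 cannot be read, and with compound 2 still at a limit it remains open whether inversion has any real effect here, or whether the ring double bond of compound 4 contributes, given that compound 1, which has the same drawn configuration without that double bond, also sits at a limit. Also open, from the compounds shown here alone, is what an added group, such as an amine or a carboxylic acid, on the core of compound 4 would do to a value this weak.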